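The compounds below may be only part of what the source reports. "The series", "measured", "known", "first", "only" and "open" are said of these compounds alone.

Measured so far:
compound 1 (`Nc1cccc(Nc2nc3ccccc3nc2S(=O)(=O)c2ccccc2)c1`): 1750 nM
compound 2 (`O=S(=O)(c1ccccc1)c1nc2ccccc2nc1Nc1ccc(C(F)(F)F)cc1`): 300 nM
Not yet measured:
compound 3 (`Nc1cccc(Nc2nc3ccccc3nc2S(=O)(=O)c2ccc(Br)cc2)c1`)

Among the compounds with values here, in a functional assay on HL-60 cells (Homo sapiens) for cytotoxicity, read by MTT assay, with a stated time of 72 h (on this read-out lower numbers stand for stronger inhibition and higher numbers for weaker inhibition), compound 1 gives 1750 nM and stands highest of the two numbers so far, with compound 2 the nearest at 300 nM on the lower side. Compound 3 keeps the 3-aminophenyl group of compound 1 and differs from it by one change (bromo in place of hydrogen on an aromatic carbon) which, cut one bond further out, reads phenyl to 4-bromophenyl. Within the data shown here, the only measured step is a 5.8-fold lower number from compound 1 to compound 2 (0.77 log units; beyond the scatter) and it replaces 3-aminophenyl with 4-(trifluoromethyl)phenyl on a nitrogen, at a different place from the new change. Among the measured compounds shown here, it shows that the series can move, but no measured step tests bromo in place of hydrogen. A small to modest step is therefore expected in this assay and it may stay within the scatter. A slight lean towards a lower number rests only on compound 1 sitting at 1750 nM as the higher of the two values. The expected shift is a 1.8-fold lower number from compound 1 to compound 3 (0.24 log units; within the scatter) as a central estimate. For compound 3 the expected value is 1000 nM with an estimated range from 350 nM to 2800 nM at the upper end.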

Compound 3, half-maximal inhibitory concentration: 1370 nM
Compound 3: the middle estimate sits 1.4-fold (0.14 log units) below what was measured; low and high end bracket the measured number.
By their numbers in this assay, from the lowest: compound 2; then compounds 3 and 1 (each within the scatter of the next).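

In this assay, within the data shown here, the step at this position is a 1.3-fold lower number from compound 1 to compound 3 (0.11 log units; within the scatter) and so gives the first reading of the phenyl group that becomes 4-bromophenyl: with the 3-aminophenyl group held constant, bromo in place of hydrogen on this aromatic carbon, para to a large group, does not separate the two compounds. The only step beyond the scatter in the series remains a 5.8-fold lower number from compound 1 to compound 2 (0.77 log units; beyond the scatter) at the group on the nitrogen, so in the compounds shown the measurable movement lies at that place and not on the phenyl group changed here. No measurement on hand bears on the reason for this result.

Open at this position is whether a group other than bromo, such as an amine, a carboxylic acid or a longer chain, would also stay within the scatter or would move the number beyond it. Among these compounds, also open is whether bromo at this place would read the same with 4-(trifluoromethyl)phenyl on the nitrogen in place of 3-aminophenyl, as the single step here was read with 3-aminophenyl only.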